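The compounds below may be only part of what the source reports. "The series", "measured", "known", "first", "only" and "open" are said of these compounds alone.

Measured so far:
- Compound 1, `COc1ccc(C(=O)/C(=C/c2ccc([N+](=O)[O-])cc2)CC(C)C)cc1`, gives 600 nM in a functional assay on NB-4 cells (Homo sapiens) for inhibition, read by XTT assay, with a stated time of 48 h; a higher number here means a weaker inhibitor, a lower number a stronger inhibitor.
- Compound 2, `COc1ccc(C(=O)/C(=C/c2ccc(Cl)cc2)CC(C)C)cc1`, gives 12100 nM in this assay.

Among the compounds with values here, compound 2 has the higher of the two numbers, so it is the weaker inhibitor; its only neighbour is compound 1, and the step between them, a 20-fold higher number from compound 1 to compound 2 (1.30 log units; beyond the scatter), came with chloro in place of nitro on an aromatic carbon. Compound 3, `COc1ccc(C(=O)/C(=C/c2ccc(C(F)(F)F)cc2)CC(C)C)cc1`, differs from compound 2 only by trifluoromethyl in place of chloro on an aromatic carbon. Within the data shown here, no measured step covers a trifluoromethyl group; the one step that exists concerns nitro against chloro, so it bears on compound 3 only by showing that a change at this one aromatic carbon can move the number far. With nothing closer to go on, the expected step of a 1.5-fold lower number from compound 2 to compound 3 (0.18 log units; within the scatter) in this assay is small, likely within the scatter, with no firm direction. Compound 3 is therefore estimated at 8000 nM, with a range from 2000 nM to 30000 nM.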

Compound 3, half-maximal inhibitory concentration: 12600 nM
Beside the measured number, compound 3's estimate is 1.6-fold (0.20 log units) below it; measured number inside the range.
By their numbers in this assay, from the lowest: compound 1; then compounds 2 and 3 (each within the scatter of the next).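

In this assay, trifluoromethyl and chloro on this aromatic carbon cannot be told apart (a 1.0-fold higher number from compound 2 to compound 3 (0.02 log units; within the scatter)), although trifluoromethyl brings 4 heavy atoms where chloro brings 1. Nitro remains the group that stands apart, since replacing it with trifluoromethyl also gives a large step (a 21-fold higher number from compound 1 to compound 3 (1.32 log units; beyond the scatter)), so the earlier loss on leaving nitro was not peculiar to chloro. No measurement shown here explains why nitro differs from the other two groups.

From the compounds shown here alone, it remains open whether nitro is unusual at this carbon or is one of several groups that give a low number: a nitrile, an amine or a carboxylic acid in the same place could fall with nitro, with the other two, or elsewhere. Going by these compounds, it is also open whether a longer chain on the shared core would keep this gap.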